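Amide aryl variation on the shared acid core

This account rests on a few compounds, and the source may have more. Where it says the series, first, only, none or still open, it means among the compounds named here.

Measured compounds:
Compound 1, `COc1ccc(C(=O)Nc2cc(Br)cc3c(=O)cc(C(=O)O)oc23)c(Cl)c1`: 4170 nM
Compound 2, `O=C(Nc1cc(Br)cc2c(=O)cc(C(=O)O)oc12)c1ccccc1`: 2750 nM

Both compounds were read in an assay on CHO cells for agonist activity at G protein-coupled receptor GPR35 (Rattus norvegicus), read by a beta-galactosidase reporter and beta-arrestin recruitment, with a stated time of 90 min; a lower number here means that less compound is needed, a higher number that more compound is needed for the effect. Within the data shown here, compound 2 holds the lowest of the two numbers, but its only neighbour is compound 1 and that step, a 1.5-fold lower number from compound 1 to compound 2 (0.18 log units; within the scatter), is within the scatter, so no order between the two can be claimed.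

Compound 3, `O=C(Nc1cc(Br)cc2c(=O)cc(C(=O)O)oc12)c1ccc(Cl)c(Cl)c1`, is not yet measured. Its change from compound 2 is 3,4-dichlorophenyl in place of phenyl on a carbonyl carbon. Among the measured compounds shown here, the only measured step that bears on the question is a 1.5-fold lower number from compound 1 to compound 2 (0.18 log units; within the scatter), where a different substitution pattern on the same ring left the number essentially unchanged. On that basis compound 3 is expected to sit close to compound 2, with the step of a 1.1-fold lower number from compound 2 to compound 3 (0.04 log units; within the scatter) estimated to be within the scatter. The estimate for compound 3 in this assay is 2500 nM, with a range from 900 nM to 7000 nM.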

Compound 3, half-maximal effective concentration: 3250 nM
Estimate against measurement, compound 3: 1.3-fold (0.11 log units) below, within the range that was stated.
By their numbers in this assay, from the lowest: compounds 2, 3 and 1 (each within the scatter of the next).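

In this assay, among these compounds, 3,4-dichlorophenyl in place of phenyl on a carbonyl carbon gives a 1.2-fold higher number from compound 2 to compound 3 (0.07 log units; within the scatter), so two chlorine atoms on the ring at this position leave no step that can be read beyond the scatter. The same group in place of 2-chloro-4-methoxyphenyl gives a 1.3-fold lower number from compound 1 to compound 3 (0.11 log units; within the scatter), so all three aryl groups now shown on this carbonyl carbon remain indistinguishable, and no order among them can be drawn. No supporting data bear on this result.

As far as these compounds go, all three groups are six-membered carbon rings with no net charge, so it remains open whether an amine, a carboxylic acid or a longer chain at this position would move the number beyond the scatter. Also open, from the compounds shown here alone, is whether this lack of separation would hold on a shared core carrying a different group in place of the bromine.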